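Acetyl in Place of Isopropyl on the Ring Nitrogen

The source may hold more compounds than are shown below. What is called first, only, known or untested is meant among the compounds shown, and "the series" means these compounds.

Going by the values given here, the three compounds measured so far share one core and differ only in the group on a nitrogen bound to an aromatic ring. In an assay on isolated protein for inhibition of serine/threonine-protein kinase TNNI3K (Homo sapiens) (a lower number here means a stronger inhibitor, a higher number a weaker inhibitor), compound 1 `CCCNc1cc(Oc2ccc(NC(=O)Nc3cccc(C(F)(F)F)c3)cc2)ncn1` gives 32 nM. Compound 2 `CNc1cc(Oc2ccc(NC(=O)Nc3cccc(C(F)(F)F)c3)cc2)ncn1` gives 40 nM, and compound 3 `CC(C)Nc1cc(Oc2ccc(NC(=O)Nc3cccc(C(F)(F)F)c3)cc2)ncn1` gives 40 nM. Compound 3 stands level with compound 2 at the digits shown, the two together the highest of the three numbers; its furthest neighbour is compound 1, with a 1.3-fold higher number from compound 1 to compound 3 (0.10 log units; within the scatter). The other steps are of the same kind: a 1.3-fold higher number from compound 1 to compound 2 (0.10 log units; within the scatter) and no change at the digits printed from compound 2 to compound 3 (within the scatter). Across these three compounds the size of the alkyl on that nitrogen leaves the number unchanged beyond the scatter.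

Compound 4 `CC(=O)Nc1cc(Oc2ccc(NC(=O)Nc3cccc(C(F)(F)F)c3)cc2)ncn1` differs from compound 3 as follows: acetyl in place of isopropyl on a nitrogen on an aromatic ring. Among the compounds with values here, no measured step exchanges an alkyl for an acyl at this place; the steps available cover only alkyl size, so they give no direct precedent. The estimate therefore takes the flat behaviour of compounds 1 to 3 as a starting point and allows a wide range. A step of a 2.3-fold higher number from compound 3 to compound 4 (0.35 log units; beyond the scatter) is expected. For compound 4 the expected value is 90 nM, with a range of 25 nM to 400 nM.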

Compound 4, half-maximal inhibitory concentration: 20 nM
Compound 4: middle estimate off by 4.5-fold (0.65 log units), on the high side; the measured number lies below the stated range.
By their numbers in this assay, from the lowest: compounds 4, 1, 2 and 3 (each within the scatter of the next).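

In this assay, exchanging an alkyl for acetyl on the nitrogen on an aromatic ring stays within the scatter against all three alkyl compounds (a 2.0-fold lower number from compound 3 to compound 4 (0.30 log units; within the scatter); a 2.0-fold lower number from compound 2 to compound 4 (0.30 log units; within the scatter); a 1.6-fold lower number from compound 1 to compound 4 (0.20 log units; within the scatter)). The flat reading at this place therefore extends beyond alkyl size: isopropylamino and acetamido carry the same count of heavy atoms but differ in a carbonyl oxygen and a double bond outside aromatic rings, and that exchange does not move the number beyond the scatter in these four compounds. Nothing in hand explains why the number holds across alkyl and acyl groups.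

The compounds shown leave open how an unsubstituted amine, a longer acyl chain such as butanoyl, a benzoyl group or a methanesulfonyl group would read on this nitrogen, and so whether any group here can shift the number beyond the scatter. They also leave open whether the same flat reading would hold with a methyl group in place of the amide hydrogen of the acetamido compound.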